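The source may hold more compounds than are shown below. What is called first, only, known or untested is meant among the compounds shown, and "the series" means these compounds.

Of the compounds shown here, three that share one core have been tested in an ADME assay on microsomes from liver (Homo sapiens) for metabolic stability, read by LC-MS, using NADPH, with a stated time of 30 min, tested at 0.1 uM; on this read-out lower numbers stand for a less stable compound and higher numbers for a more stable compound. Compound 1 `C[C@@]1(c2cc(NC(=O)c3cnc(OCF)cn3)ccc2F)C=C(CF)OC(N)=N1` gives 86% in this assay, the highest of the three numbers. Compound 2 `C[C@@]1(c2cc(NC(=O)c3ncc(C#N)cc3Cl)ccc2F)C=C(CF)OC(N)=N1` gives 57%, and compound 3 `C[C@@]1(c2cc(NC(=O)c3ncc(OCF)nc3N)ccc2F)C=C(CF)OC(N)=N1` gives 67%. Exchanging the whole group on the carbonyl carbon brought a number 29 percentage points lower from compound 1 to compound 2 (beyond the scatter), while adding an amino group to that ring brought a number 19 percentage points lower from compound 1 to compound 3 (beyond the scatter). Between the two lower compounds the difference was a number 10 percentage points higher from compound 2 to compound 3 (within the scatter).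

Compound 4 `C[C@@]1(c2cc(NC(=O)c3coc(CF)n3)ccc2F)C=C(CF)OC(N)=N1` has not yet been measured in this assay. It differs from compound 1 in one place: 2-(fluoromethyl)-1,3-oxazol-4-yl in place of 5-(fluoromethoxy)pyrazin-2-yl on a carbonyl carbon. For the measured compounds named here, the step from compound 1 to compound 2 bears on this most, since it also exchanges the whole group on the carbonyl carbon; the step from compound 1 to compound 3 changes only one part of that group. Both steps away from compound 1 lowered the number beyond the scatter, so a modest drop is expected here as well, roughly a number 21 percentage points lower from compound 1 to compound 4 (beyond the scatter). Compound 4 is therefore estimated at 65%, with a range from 45% to 85%.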

Compound 4, percent of the compound remaining: 76%
Compound 4: middle estimate off by 11 percentage points, on the low side; the range from low to high includes it.
By their numbers in this assay, from the lowest: compounds 2, 3, 4 and 1 (each within the scatter of the next, the first and the last beyond it).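

In this assay, for the compounds shown here, replacing 5-(fluoromethoxy)pyrazin-2-yl with 2-(fluoromethyl)-1,3-oxazol-4-yl gives a number 10 percentage points lower from compound 1 to compound 4 (within the scatter), making this the first exchange of the whole group on the carbonyl carbon that stays within the scatter of compound 1, and it shows that this place tolerates a five-membered aromatic ring with fewer heavy atoms. The new ring also separates two earlier compounds differently: the comparison with the amino-bearing pyrazine gives a number 9 percentage points higher from compound 3 to compound 4 (within the scatter), whereas the comparison with the 3-chloro-5-cyanopyridin-2-yl group gives a number 19 percentage points higher from compound 2 to compound 4 (beyond the scatter), so only the latter step exceeds the scatter. No measurement is available that explains any of these numbers.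

The compounds shown cannot separate the contribution of the five-membered ring from that of its fluoromethyl group, a question that a plain methyl or a methoxy group on the same ring could address. Going by these compounds, it also remains open how an amine on the 1,3-oxazole would compare, given that the amino group on the pyrazine gave a lower number than compound 1.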